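A Sulfonate Tail on Compound 3: What to Expect

The compounds below may be only part of what the source reports. "The series", "measured", "known", "first", "only" and "open" are said of these compounds alone.

Compound 1, `CC(C)n1c(=O)n(C(=O)NCC2CCNCC2)c2ccccc21`: 15.9 nM
Compound 2, `COc1ccc2[nH]cc(C(=O)NC3CCNCC3)c2c1`: 100000000 nM
Compound 3, `CCCCCN1CCC(NC(=O)c2cc(Cl)c(N)cc2OC)CC1`: 25.1 nM

These three compounds were tested in a functional assay on HEK293 cells for agonist activity at 5-hydroxytryptamine receptor 4 (Homo sapiens), read by cAMP accumulation; a higher number here means that more compound is needed for the effect, a lower number that less compound is needed. Among them, compound 3 has the second highest number; its nearest neighbour is compound 1, whose value lies within the usual scatter, while compound 2 stands far higher, well beyond the scatter. Compound 4, `COc1cc(N)c(Cl)cc1C(=O)NC1CCN(CCCCCCCCS(=O)(=O)O)CC1`, has not yet been measured. It differs from compound 3 in one place: 3-sulfopropyl in place of hydrogen on a saturated chain carbon, five bonds along the chain from an amine nitrogen in a ring. Among the compounds with values here, no measured pair in this set shows what such a change does, so the expectation rests on compound 3 alone. A modest loss is expected, so compound 4 is estimated at 80 nM, between 15 nM and 400 nM, an expected step of a 3.2-fold higher number from compound 3 to compound 4 (0.50 log units; beyond the scatter).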

Compound 4, half-maximal effective concentration: 1000 nM
For compound 4 the middle estimate is 13-fold (1.10 log units) below the measured one; measured number above the stated range.
By their numbers in this assay, from the lowest: compounds 1 and 3 (each within the scatter of the next); then compound 4; then compound 2.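

At the saturated chain carbon, five bonds along the chain from an amine nitrogen in a ring, a substituent can be added without abolishing the effect, but at a cost: in this assay, 3-sulfopropyl in place of hydrogen gives a 40-fold higher number from compound 3 to compound 4 (1.60 log units; beyond the scatter) in this set's first step at this place. Nothing available explains the size of this step.

Going by these compounds, it remains open whether a carboxylic acid or an amine at the end of the chain would cost as much as the sulfo group. A shorter chain carrying the sulfo group is equally untested here.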